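Swapping a diaryl ether for a diaryl thioether

The compounds below may be only part of what the source reports. "The series", "measured", "known", "first", "only" and "open" are said of these compounds alone.

Measured compounds:
- compound 1, `Nc1cc(N)c2nc(-c3ccccc3)c(Oc3ccc(Cl)c(Cl)c3)nc2c1`: 32400 nM
- compound 2, `CCOC(=O)[C@H](CCC(=O)O)NC(=O)c1ccc(CNc2nc3cc(N)cc(N)c3nc2-c2ccccc2)cc1`: < 100000 nM

Compound 1 was tested in a functional assay on IGROV-1 cells (Homo sapiens) for inhibition, read by sulforhodamine B assay, with a stated time of 48 h (a lower number here means a stronger inhibitor of growth, a higher number a weaker inhibitor of growth), and gave 32400 nM. That is the only number shown for this shared core. Compound 2 shows only a limit in this assay, < 100000 nM, and the reading of compound 2 is therefore not a number that can be set against compound 1 (the limit of < 100000 nM in this assay, at which 1 of the 2 values shown sits).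

Compound 3, `COc1ccc(Sc2nc3cc(N)cc(N)c3nc2-c2ccccc2)cc1`, has not been measured. It differs from compound 1 in one place: (4-methoxyphenyl)sulfanyl in place of 3,4-dichlorophenoxy on an aromatic carbon. The change keeps the same count of heavy atoms and the same single carbon-only aromatic ring, while exchanging the two chlorines and the ether oxygen for a sulfur and a methoxy group.

Within the data shown here, because no step between two measured compounds is available in this assay, no direction can be read from the data. The step from compound 1 to compound 3 is expected to fall within the scatter, and is estimated as a 1.1-fold lower number from compound 1 to compound 3 (0.03 log units; within the scatter). For compound 3 the estimated value in this assay is 30000 nM, within a range from 8000 nM to 100000 nM.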

Compound 3, concentration for total growth inhibition: < 100000 nM
Compound 3: no number, only a limit (the forecaster's own chance of this, stated with the estimate: 20%); the middle value does not contradict the limit.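

In this assay compound 3 gives < 100000 nM, which is a limit and not a number. No new step can be read between compound 1 and compound 3: the limit of < 100000 nM in this assay, at which 2 of the 3 values shown sit.

The compounds shown leave open whether (4-methoxyphenyl)sulfanyl in place of 3,4-dichlorophenoxy changes the number in this assay, and in which direction.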